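Capping the hydroxy group of compound 3

The source may hold more compounds than are shown below. What is called first, only, known or untested is meant among the compounds shown, and "the series" means these compounds.

Measured in a functional assay on A549 cells (Homo sapiens) for inhibition, read by MTT assay, with a stated time of 72 h; a higher number here means a weaker inhibitor, a lower number a stronger inhibitor:
- compound 1 `CO[C@@H]1[C@H]2OC(=O)C[C@H]2O[C@@H]1C(=O)c1ccccc1`: 2580 nM
- compound 2 `CO[C@@H]1[C@H]2OC(=O)C[C@H]2O[C@@H]1C(O)(c1ccccc1)c1ccccc1`: 15100 nM
- compound 3 `CO[C@@H]1[C@H]2OC(=O)C[C@H]2O[C@@H]1[C@H](O)c1ccccc1`: 23600 nM

Compound 3, at 23600 nM, lies within the usual scatter of compound 2, and its number is higher than that of compound 1 by more than the scatter. Compound 4 `CO[C@@H]1[C@H]2OC(=O)C[C@H]2O[C@@H]1[C@H](OC)c1ccccc1` makes one change, hydroxy to methoxy: methyl in place of hydrogen on an oxygen on a saturated carbon. Among the measured compounds shown here, no measured pair shows this change, so any forecast is loose. Compound 1, which has no hydroxy group, gives 2580 nM, and this tilts the expectation slightly downward in this assay. The expected change is small, a 1.6-fold lower number from compound 3 to compound 4 (0.20 log units; within the scatter). For compound 4 the estimated value is 15000 nM, with an expected range of 5000 nM to 40000 nM.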

Compound 4, half-maximal inhibitory concentration: 26300 nM
Compound 4: middle estimate off by 1.8-fold (0.24 log units), on the low side; measured number inside the range.
By their numbers in this assay, from the lowest: compound 1; then compounds 2, 3 and 4 (each within the scatter of the next).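

Going from hydroxy to methoxy gives a 1.1-fold higher number from compound 3 to compound 4 (0.05 log units; within the scatter) in this assay, the first step here in which only one place differs. Methyl can therefore take the place of the hydrogen on this oxygen with no difference that stands out from repeat measurements, so compound 3 and compound 4 cannot be told apart in this cell test. Nothing shown offers an explanation for this result. Still open, on these data alone, is whether a larger group on this oxygen, such as benzyl or acetyl, would read the same, and whether an amine in place of the hydroxy would.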